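A few compounds are considered here, and "the series" means these few. Any claim that something is new, unique, unknown or untested is made for them only; others in the source may bear on it.

In an ADME assay on HEK293 cells (Homo sapiens) for cytotoxicity, read by CellTiter-Glo and resazurin assay, with a stated time of 72 h (a lower number here means that less compound is needed, a higher number that more compound is needed for the effect), compound 3 `CCOC(=O)CCCCCOc1cccc(CN(C(=O)c2ccc(-c3cccc(C(C)=O)c3)cc2)C(C)C)c1` returns only a limit, > 26000 nM, and that is where it stands: no number, only the edge of what the assay reports, as with the two other values on record. Compound 2 `CCOC(=O)CCCCCOc1cccc(CN(C(=O)c2ccc(-c3cccc4ccccc34)cc2)C(C)C)c1` also returns a limit, > 26000 nM. Compound 1 `CC(C)N(Cc1cccc(OCCCCCC(=O)O)c1)C(=O)c1ccc(-c2ccc3[nH]ccc3c2)cc1` likewise gives a limit, > 26000 nM. Among the measured compounds shown here, the one step between measured compounds, a step that the two limits leave unreadable from compound 2 to compound 3, is left unreadable by the two limits, and the only evidence is the limit of > 26000 nM in this assay, at which 3 of the 3 values shown sit. Compound 4 `CCOC(=O)CCCCCOc1cccc(CN(C(=O)c2ccc(-c3ccc4[nH]ccc4c3)cc2)C(C)C)c1` differs from compound 3 by 1H-indol-5-yl in place of 3-acetylphenyl on an aromatic carbon. Compound 1 carries the same 1H-indol-5-yl group and, as said, gives only a limit. For the measured compounds named here, no measured step bears on this change with a readable size, so nothing beyond the scatter is expected in this assay. The step of a number no higher from compound 3 to compound 4 (the limit leaves the size open) is therefore estimated to stay within the scatter. Compound 4 is expected to give 26000 nM, between 13000 nM and 52000 nM, most likely reported once more as a limit rather than a number.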

Compound 4, half-maximal effective concentration: > 26000 nM
Compound 4 was reported as a limit; the forecaster's own chance of this, stated with the estimate: 85%; the middle value sits exactly at the limit.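

Compound 4 returns only a limit, so its steps from compound 1, compound 2 and compound 3 cannot be read in this assay. The compounds shown leave open whether any of these changes affects the concentration needed for cytotoxicity, because all the values rest on one edge: the limit of > 26000 nM in this assay, at which 4 of the 4 values shown sit.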